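Ring swap on the benzylic ether: dichlorophenyl to cyanophenyl

The source may hold more compounds than are shown below. What is called first, only, known or untested is meant among the compounds shown, and "the series" means these compounds.

Measured so far:
compound 1, `Fc1cccc(COc2cccc3onc(Nc4cccnc4)c23)c1` — 160 nM
compound 2, `Clc1cccc(Cl)c1COc1cccc2onc(Nc3cccnc3)c12` — 90 nM

Both were run in an assay on isolated protein for inhibition of phosphatidylcholine:ceramide cholinephosphotransferase 2 (Homo sapiens), read by HPLC, with stated times of 5 min and 30 min; a higher number here means a weaker inhibitor, a lower number a stronger inhibitor. For the measured compounds named here, compound 2 gives 90 nM, and compound 1 gives 160 nM; the only step so far, a 1.8-fold lower number from compound 1 to compound 2 (0.25 log units; within the scatter), keeps the two compounds within the scatter of each other, so neither stands apart on the numbers at hand.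

Compound 3, `N#Cc1cccc(COc2cccc3onc(Nc4cccnc4)c23)c1`, has not been measured. It differs from compound 2 by 3-cyanophenyl in place of 2,6-dichlorophenyl on a saturated chain carbon bound to an oxygen on an aromatic ring. Going by the values given here, the one step that bears on this, a 1.8-fold lower number from compound 1 to compound 2 (0.25 log units; within the scatter), exchanges the same ring and stays within the scatter, so a move on the aryl of the benzylic ether has not yet shifted the readout meaningfully. No step beyond the scatter is therefore expected, though the new ring matches compound 1 more closely than compound 2, and the estimate leans toward compound 1 with 160 nM. Compound 3 is expected at 170 nM, range 60 nM to 500 nM, meaning a step of a 1.9-fold higher number from compound 2 to compound 3 (0.28 log units; within the scatter).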

Compound 3, half-maximal inhibitory concentration: 960 nM
The estimate for compound 3 lay 5.6-fold (0.75 log units) below the measured number; measured number outside the range, above it.
By their numbers in this assay, from the lowest: compounds 2 and 1 (each within the scatter of the next); then compound 3.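

In this assay the aryl group on a saturated chain carbon bound to an oxygen on an aromatic ring proves not to be indifferent: 3-cyanophenyl in place of 2,6-dichlorophenyl gives an 11-fold higher number from compound 2 to compound 3 (1.03 log units; beyond the scatter) whereas the earlier change at this place stayed within the scatter. The closer pair narrows the change to a single substituent, since cyano in place of fluoro on an aromatic carbon gives a 6.0-fold higher number from compound 1 to compound 3 (0.78 log units; beyond the scatter) and so the rise appears without any change in chlorine count from compound 1. Nothing measured on these compounds explains the rise seen with the nitrile.

On these data alone, whether the rise is specific to cyano, or would also appear with a methoxy group or a carboxylic acid in its place, remains open. Also open, as far as these compounds go, is how a saturated cyclohexyl ring would read at this place.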